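This account rests on a few compounds, and the source may have more. Where it says the series, first, only, none or still open, it means among the compounds named here.

Compound 1 `CCSCCC12CCC(c3nnc(-c4ccccc4C(F)(F)F)n3C)(CC1)CC2` gives 79% in a functional assay on the whole organism (strain ICR) for inhibition, with Mus musculus as the target, with a stated time of 4 h, at a dose of 10 mg/kg by the oral route; on this read-out higher numbers stand for more inhibition at the one dose given (going by the name of the read-out) and lower numbers for less inhibition. Compound 2 `Cn1c(-c2ccccc2C(F)(F)F)nnc1C12CCC(CCS(=O)(=O)C(C)(C)C)(CC1)CC2` gives 65%. Compound 3 `CCCCCC12CCC(c3nnc(-c4ccccc4C(F)(F)F)n3C)(CC1)CC2` gives 98%.

Compound 3 stands highest of the three numbers: the nearest is compound 1, and the step of a number 19 percentage points higher from compound 1 to compound 3 (beyond the scatter) lies beyond the scatter; the furthest is compound 2, with a number 33 percentage points higher from compound 2 to compound 3 (beyond the scatter) being large. Within the data shown here, the one further step, a number 14 percentage points lower from compound 1 to compound 2 (beyond the scatter), is modest. Compound 4 `CC(O)CCCC12CCC(c3nnc(-c4ccccc4C(F)(F)F)n3C)(CC1)CC2` differs from compound 3 by hydroxy in place of hydrogen on a saturated chain carbon bound to two saturated chain carbons. Among the measured compounds shown here, no measured step puts a hydroxy in place of hydrogen, so the guidance is indirect. What the measured steps share with it is that each alters the same chain hanging from the shared core: propyl in place of ethylsulfanyl and propyl in place of (tert-butyl)sulfonyl both raised inhibition, the second strongly. Going the other way, from a plain chain to one carrying a hydroxy, compound 4 is therefore expected to show a downward step, a number 18 percentage points lower from compound 3 to compound 4 (beyond the scatter), of modest size rather than a large one. Compound 4 is estimated at 80%, within 60% to 97%.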

Compound 4, a percentage reported as inhibition, in the whole organism at one dose (the size of the read-out at that dose, not a potency): 97%
Estimate against measurement, compound 4: 17 percentage points below, within the range that was stated.
By their numbers in this assay, from the lowest: compound 2; then compound 1; then compounds 4 and 3 (each within the scatter of the next).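

In this assay, hydroxy in place of hydrogen on a saturated chain carbon bound to two saturated chain carbons gives a number 1 percentage points lower from compound 3 to compound 4 (within the scatter), so this chain carbon accepts the hydroxy without a change beyond the scatter. The 2-hydroxypropyl group also keeps the number clear of both sulfur-bearing chains, with a number 32 percentage points higher from compound 2 to compound 4 (beyond the scatter) for its swap with (tert-butyl)sulfonyl and a number 18 percentage points higher from compound 1 to compound 4 (beyond the scatter) for its swap with ethylsulfanyl, so among these compounds an oxygen on the chain does not by itself bring the lower numbers seen for compound 1 and compound 2. Nothing available explains why the hydroxy is accepted here.

As far as these compounds go, whether an amine or a carboxylic acid on this chain carbon, or a longer chain carrying the hydroxy, would hold the number remains open. This single-dose read-out also gives no potency, so any difference in potency between compound 3 and compound 4 stays unresolved.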